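Putting a Substituent Back on the Phenyl Ring

This account rests on a few compounds, and the source may have more. Where it says the series, first, only, none or still open, it means among the compounds named here.

Compound 1 `CC1=NN(c2ccc(C)cc2)C(=O)C12C=CC(=O)C=C2c1cccc(C)c1` carries a methyl on one of its aromatic carbons. In a functional assay on HCT-116 cells (Homo sapiens) for antiproliferative activity, read by CCK-8 assay, with a stated time of 72 h (on this read-out higher numbers stand for weaker inhibition and lower numbers for stronger inhibition), compound 1 gives 8340 nM. Compound 2 `CC1=NN(c2ccccc2)C(=O)C12C=CC(=O)C=C2c1cccc(C)c1` differs only by hydrogen in place of that methyl. In this assay compound 2 gives > 100000 nM, which is a limit of the assay rather than a number. Removing the methyl thus brought an at least 11-fold higher number from compound 1 to compound 2 (1.07 log units; beyond the scatter), and the true size of that loss cannot be read because of the limit of > 100000 nM in this assay, at which 1 of the 2 values shown sits. Compound 3 `CC1=NN(c2ccc(Cl)cc2)C(=O)C12C=CC(=O)C=C2c1cccc(C)c1` takes the next step: chloro in place of hydrogen on an aromatic carbon. For the measured compounds named here, only the step from compound 1 to compound 2 bears on it, and it showed how much a group at that carbon was worth. Chloro is not methyl, so the size of any recovery is uncertain, but a lower number, back toward compound 1, is expected. Compound 3 is therefore expected to give 12000 nM, within 3000 nM to 60000 nM, an expected step of an at least 8.3-fold lower number from compound 2 to compound 3 (0.92 log units; beyond the scatter).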

Compound 3, half-maximal inhibitory concentration: 13300 nM
Compound 3: the middle estimate sits 1.1-fold (0.04 log units) below what was measured; measured number inside the range.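

Chloro on this carbon, para to a large group, also restores activity in this assay, with an at least 7.5-fold lower number from compound 2 to compound 3 (0.87 log units; beyond the scatter). The true size of that gain cannot be read, because compound 2 stands at a limit of the assay rather than at a number: the limit of > 100000 nM in this assay, at which 1 of the 3 values shown sits. Methyl and chloro cannot be told apart here, with a 1.6-fold higher number from compound 1 to compound 3 (0.20 log units; within the scatter), so the benefit of a group on this carbon now holds for two different groups rather than for methyl alone.

The compounds shown leave open whether almost any group on this carbon would serve or only some would, a question that a methoxy group, an amine or a carboxylic acid could help to answer. They also do not show whether chloro or methyl would do as well on another carbon of this ring.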